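Adding a methyl group to compound 1: working notes

The compounds below may be only part of what the source reports. "The series", "measured", "known", "first", "only" and "open" are said of these compounds alone.

Values so far in a functional assay on LNCaP cells (Homo sapiens) for cytotoxicity, read by MTT assay, with a stated time of 5 days (on this read-out higher numbers stand for weaker inhibition of growth and lower numbers for stronger inhibition of growth), as measured
compound 1 `Cc1ccc(NS(=O)(=O)c2ccccc2)c([N+](=O)[O-])c1` gives 2.95 nM
compound 2 `O=S(=O)(Nc1ccccc1)c1ccccc1` gives 53500 nM

Compound 1 holds the lower of the two values, and its gap to compound 2 lies beyond the scatter. Among the compounds with values here, with only two numbers, this placing says little about any wider series.

Compound 3 `Cc1ccc(S(=O)(=O)Nc2ccc(C)cc2[N+](=O)[O-])cc1` keeps the core of compound 1 and carries methyl in place of hydrogen on an aromatic carbon, para to a large group (methyl in place of hydrogen on an aromatic carbon). The same difference reads as phenyl to 4-methylphenyl.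

Within the data shown here, no measured pair in this assay shows this change, so the data give no direct guide to its size. The expected direction is toward a higher number, since compound 1 at 2.95 nM already stands at the low end of the values seen. The estimate is a 5.1-fold higher number from compound 1 to compound 3 (0.71 log units; beyond the scatter) and this expected step is moderate, although a result within the scatter would not surprise. Compound 3 is estimated at 15 nM with an expected range from 1.5 nM to 300 nM on this read-out.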

Compound 3, concentration for 50% growth inhibition: 39800 nM
Estimate against measurement, compound 3: 2700-fold (3.42 log units) below, outside the stated range (above it).
By their numbers in this assay, from the lowest: compound 1; then compounds 3 and 2 (each within the scatter of the next).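

In this assay, within the data shown here, the change from phenyl to 4-methylphenyl gives a 13000-fold higher number from compound 1 to compound 3 (4.13 log units; beyond the scatter), the first step that differs in one place only. The value of compound 1 therefore does not carry over to this substitution: on this aromatic carbon, para to a large group, hydrogen and methyl are far from equivalent, and this single added carbon is enough to move compound 3 to 39800 nM against compound 1 at 2.95 nM, a large step beyond the scatter. Nothing at hand accounts for the size of this step.

One pair cannot separate a requirement for hydrogen at this position from an objection to methyl in particular, so a fluorine atom, a chlorine atom, a methoxy group, an amine or a longer chain such as ethyl at the same carbon would each help to define how far the effect extends. Also open, from the compounds shown here alone, is whether methyl on the other carbons of this ring gives a step of similar size, or whether the sharp change is confined to this one position.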